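The source may hold more compounds than are shown below. What is called first, only, known or untested is meant among the compounds shown, and "the series" means these compounds.

Values so far in a functional assay on L1210 cells (Mus musculus) for antiproliferative activity, read by cell counting, with a stated time of 2 days; a higher number here means a weaker inhibitor, a lower number a stronger inhibitor
compound 1 `COc1cc(C(=O)c2sc(Nc3ccc(F)cc3)nc2N)cc(OC)c1OC` gives 900 nM
compound 2 `COc1ccc(Nc2nc(N)c(C(=O)c3ccc(OC)c(OC)c3)s2)cc1` gives 38 nM
compound 3 `COc1ccc(Nc2nc(N)c(C(=O)c3ccc(Br)cc3)s2)cc1` gives 110 nM

Compound 1 has the highest number of the three and is the weakest inhibitor here. Its gaps to both compound 2 (38 nM) and compound 3 (110 nM) lie beyond the scatter. Both of those compounds differ from compound 1 in more than one place, so their values cannot be assigned to any single structural feature.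

Compound 4 `COc1cc(C(=O)c2sc(Nc3ccc(Cl)cc3)nc2N)cc(OC)c1OC` keeps the rest of compound 1 and has chloro in place of fluoro on an aromatic carbon, para to a large group (chloro in place of fluoro on an aromatic carbon). The same difference can be read as 4-fluorophenyl to 4-chlorophenyl. For the measured compounds named here, no pair of measured compounds differs in only one place, so the series offers no direct precedent for this change. The expectation therefore rests on compound 1 (900 nM) and on the small size of the exchange, with no shift beyond the scatter anticipated in this assay. The expected step of a 1.3-fold lower number from compound 1 to compound 4 (0.11 log units; within the scatter) is estimated to stay within the scatter. Compound 4 is estimated at 700 nM, with an expected range from 250 nM to 2000 nM.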

Compound 4, half-maximal inhibitory concentration: 420 nM
The estimate for compound 4 lay 1.7-fold (0.22 log units) above the measured number; the range from low to high includes it.
By their numbers in this assay, from the lowest: compound 2; then compound 3; then compound 4; then compound 1.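

In this assay, for the compounds shown here, compound 1 and compound 4 form the only pair that differs in one place, and chloro in place of fluoro on the aromatic carbon para to a large group gives a 2.1-fold lower number from compound 1 to compound 4 (0.33 log units; beyond the scatter). This gives the series its first direct reading at this position: the position responds to a change of halogen, with the 4-chlorophenyl compound the stronger inhibitor of the two, although the step is modest and only just clears the scatter. No measurement at hand accounts for the step, so the difference between chloro and fluoro remains an observation without an explanation.

On these data alone, a single exchange gives no trend, so it remains open how a nitrile, a trifluoromethyl group or an amine at this position would compare with chloro and fluoro on the core of compound 1. As far as these compounds go, it is also open whether the same exchange would give a similar step with a different aroyl group, such as the 3,4-dimethoxybenzoyl of compound 2 or the 4-bromobenzoyl of compound 3.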